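Shortening One Ester Chain in Compound 2

A few compounds are considered here, and "the series" means these few. Any claim that something is new, unique, unknown or untested is made for them only; others in the source may bear on it.

The two measured compounds share a core and differ only in their ester groups. Compound 1, `COC(=O)C1=C(C)NC(C)=C(C(=O)OC)C1c1ccc(-c2cc(=O)cc(-c3ccccc3)o2)cc1`, carries methyl esters; in an assay on isolated protein (strain albino) for inhibition of Voltage-dependent L-type calcium channel subunit alpha-1C (Cavia porcellus) (on this read-out higher numbers stand for weaker inhibition and lower numbers for stronger inhibition), compound 1 gives 4710 nM. Compound 2, `CCOC(=O)C1=C(C)NC(C)=C(C(=O)OCC)C1c1ccc(-c2cc(=O)cc(-c3ccccc3)o2)cc1`, carries ethyl esters; in this assay compound 2 gives 12200 nM. Of the two numbers, compound 2 stands at the higher one, and its gap to compound 1 lies beyond the usual scatter of such measurements, so compound 2 is the weaker inhibitor of the pair.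

Compound 3, `CCOC(=O)C1=C(C)NC(C)=C(C(=O)OC)C1c1ccc(-c2cc(=O)cc(-c3ccccc3)o2)cc1`, sits between them: it keeps one ethyl ester of compound 2 and carries the methyl ester of compound 1 on the other side. The change from compound 2 reads (hydrogen in place of methyl on a saturated chain carbon bound to an oxygen next to a carbonyl group). Within the data shown here, no step of exactly this kind has been measured, but the two values at hand show that trading ethyl for methyl on both esters lowers the number, so a partial move in the same direction is a reasonable guess. Compound 3 is therefore expected to show a modest downward step, a 1.6-fold lower number from compound 2 to compound 3 (0.21 log units; within the scatter), with an estimate of 7500 nM and a range from 3500 nM to 16000 nM in this assay.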

Compound 3, half-maximal inhibitory concentration: 94400 nM
Compound 3: middle estimate off by 13-fold (1.10 log units), on the low side; measured number outside the range, above it.
By their numbers in this assay, from the lowest: compound 1; then compound 2; then compound 3.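

In this assay, replacing one ethoxycarbonyl with methoxycarbonyl gives a 7.7-fold higher number from compound 2 to compound 3 (0.89 log units; beyond the scatter) and does not move the number toward the lower value of compound 1. The opposite change, methyl in place of hydrogen on a saturated chain carbon bound to an oxygen next to a carbonyl group, gives a 20-fold higher number from compound 1 to compound 3 (1.30 log units; beyond the scatter) and so also raises the number, which means that the direction of this single change depends on what the other ester carries, and among these three compounds the one with two different esters has the highest number. Nothing at hand explains this reversal, and no measurement bears on its cause.

The three compounds leave open whether the high number belongs to the ethyl and methyl pairing alone or would recur with a longer chain, such as a propyl or butyl ester, paired with a methyl ester. They also leave open how a carboxylic acid or an amide in place of one ester would read in this assay on this shared core.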